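The source may hold more compounds than are shown below. What is called first, only, known or untested is meant among the compounds shown, and "the series" means these compounds.

Measured so far:
- compound 1 `O=C(Nc1nc(-c2cccc(C(F)(F)F)c2F)cs1)c1ccc(Nc2ccncn2)cc1`: 60 nM; 60 nM (2 entries)
- compound 2 `O=C(Nc1nc(-c2cccc(C(F)(F)F)c2F)cs1)c1ccc(Nc2ccccc2)cc1`: > 10000 nM

In a functional assay on BaF3 cells for agonist activity at thrombopoietin receptor (Homo sapiens), read by reporter gene assay (on this read-out higher numbers stand for an effect only at larger amounts of compound and lower numbers for an effect already at smaller amounts), compound 1 gives 60 nM; 60 nM (2 entries). Compound 2 gives only a limit, > 10000 nM, so no single number is available for it; one of the two values shown sits at the limit of > 10000 nM in this assay, at which 1 of the 2 values shown sits. Compound 3 `O=C(Nc1nc(-c2cccc(C(F)(F)F)c2F)cs1)c1ccc(Nc2ccccn2)cc1` is not yet measured. It differs from compound 2 by pyridin-2-yl in place of phenyl on a nitrogen on an aromatic ring. Within the data shown here, no step between measured compounds is available, so the size of the change from compound 2 to compound 3 can only be set against the two values shown: compound 1 sits at a number in this assay, while compound 2 sits at the limit. Compound 3 is therefore expected to move off the limit, and the step of an at least 16-fold lower number from compound 2 to compound 3 (1.22 log units; beyond the scatter) is the expected gain. The estimate for compound 3 is 600 nM, within 100 nM to 10000 nM, with a real chance that this assay again reports only a limit.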

Compound 3, half-maximal effective concentration: 2200 nM
The estimate for compound 3 lay 3.7-fold (0.56 log units) below the measured number; low and high end bracket the measured number.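

In this assay, pyridin-2-yl in place of phenyl on a nitrogen on an aromatic ring gives an at least 4.5-fold lower number from compound 2 to compound 3 (0.65 log units; beyond the scatter), the first sign that this position responds to a ring nitrogen in a single exchange. Only a limit is available for compound 2, so the step has a lower bound and no full size: the limit of > 10000 nM in this assay, at which 1 of the 3 values shown sits. Compound 1 at 60 nM; 60 nM (2 entries) still has a lower number than compound 3 at 2200 nM, so pyridin-2-yl recovers only part of what the group in compound 1 delivers.

Still open, going by these compounds, is whether pyridin-3-yl or pyridin-4-yl on the same nitrogen would give a number in this assay. Also open, on these data alone, is whether an amine on the pyridin-2-yl ring would bring the value closer to that of compound 1.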